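A few compounds are considered here, and "the series" means these few. Any claim that something is new, unique, unknown or untested is made for them only; others in the source may bear on it.

Compound 1, `CC(C)(O)C#Cc1cc(C(O)(C(F)(F)F)C(F)(F)F)cnc1N1CCN(S(=O)(=O)c2ccc(N)nc2)CC1`, gives 16 mL.min-1.g-1 in an ADME assay (liver) for metabolic stability, with Liver microsome (Rattus norvegicus) as the target, using microsomes and NADPH, with a stated time of 30 min, tested at 1 uM; a lower number here means slower removal, a higher number faster removal of the compound.
Compound 2, `CC(C)(C)n1cc(-c2cc(C(O)(C(F)(F)F)C(F)(F)F)cnc2N2CCN(S(=O)(=O)c3ccc(N)nc3)CC2)cn1`, gives 459 mL.min-1.g-1 in this assay.
Compound 3, `CS(=O)(=O)c1ccc(-c2cc(C(O)(C(F)(F)F)C(F)(F)F)cnc2N2CCN(S(=O)(=O)c3ccc(N)nc3)CC2)cc1`, gives 103 mL.min-1.g-1 in this assay.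

Among these three, compound 3 stands second highest; the nearest neighbour is a 4.5-fold lower number from compound 2 to compound 3 (0.65 log units; beyond the scatter), and the furthest is a 6.4-fold higher number from compound 1 to compound 3 (0.81 log units; beyond the scatter). Compound 4, `Nc1ccc(S(=O)(=O)N2CCN(c3ncc(C(O)(C(F)(F)F)C(F)(F)F)cc3-c3ccc4c(c3)CC(=O)N4)CC2)cn1`, has not yet been measured in this assay. It differs from compound 3 in one place: a group of 10 heavy atoms (8 carbon, 1 nitrogen, 1 oxygen; one five-membered non-aromatic ring with 1 hetero atom, one six-membered aromatic ring of carbon only) in place of a group of 10 heavy atoms (7 carbon, 2 oxygen, 1 sulfur; one six-membered aromatic ring of carbon only), on an aromatic carbon.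

Going by the values given here, no measured step involves the entering group, so the only guidance comes from the three swaps at the same aromatic carbon. Those steps were a 29-fold higher number from compound 1 to compound 2 (1.46 log units; beyond the scatter), a 6.4-fold higher number from compound 1 to compound 3 (0.81 log units; beyond the scatter) and a 4.5-fold lower number from compound 2 to compound 3 (0.65 log units; beyond the scatter); every change at this position moved the number beyond the scatter, by a modest to large amount, and the two aryl-bearing compounds sit well above compound 1. Since compound 4 also carries a six-membered aromatic ring of carbon only at this position, the number is expected to stay in the region of compound 3 rather than return to that of compound 1, with a direction that cannot be called from the available steps. Compound 4 is therefore estimated at 80 mL.min-1.g-1, within 30 mL.min-1.g-1 to 250 mL.min-1.g-1, corresponding to an expected step of a 1.3-fold lower number from compound 3 to compound 4 (0.11 log units; within the scatter).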

Compound 4, intrinsic clearance in microsomes: 119 mL.min-1.g-1
Compound 4: middle estimate off by 1.5-fold (0.17 log units), on the low side; the measured number falls inside the stated range.
By their numbers in this assay, from the lowest: compound 1; then compounds 3 and 4 (each within the scatter of the next); then compound 2.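

In this assay, the change at this aromatic carbon gives a 1.2-fold higher number from compound 3 to compound 4 (0.06 log units; within the scatter), so two quite different groups, each with a six-membered aromatic ring of carbon only, cannot be told apart here, even though the entering group has a five-membered non-aromatic ring with 1 hetero atom and 1 hydrogen-bond donor where the leaving 4-(methylsulfonyl)phenyl has 0. The same entering group stays clearly separated from the other two groups tested at this position, with a 3.9-fold lower number from compound 2 to compound 4 (0.59 log units; beyond the scatter) and a 7.4-fold higher number from compound 1 to compound 4 (0.87 log units; beyond the scatter), so among these four compounds the pair bearing this carbon-only aromatic ring sits between the 1-(tert-butyl)-1H-pyrazol-4-yl and 3-hydroxy-3-methylbut-1-yn-1-yl compounds. No measurement shown here accounts for this grouping or for the size of any of these steps.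

The compounds shown leave open whether an unsubstituted phenyl, or a phenyl carrying an amine or a carboxylic acid, would fall with compound 3 and compound 4 or move away from them. They also leave open whether a 3-methylbut-1-yn-1-yl group without the hydroxyl, or a longer chain ending in a hydroxyl, would stay near compound 1.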